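The compounds below may be only part of what the source reports. "The series", "measured", "known", "first", "only" and "open" are said of these compounds alone.

Compound 3 `COc1cc(NC(C)CCCNC(=O)NN)c2ncccc2c1` carries a free terminal amine on its side chain and sits at the weak end of the small set. In a functional assay on MCF7 cells (Homo sapiens) for inhibition, read by MTT assay, with a stated time of 4 days (a lower number here means a stronger inhibitor, a higher number a weaker inhibitor), compound 3 gives 16000 nM. Compound 1 `COc1ccc(/C(=N/NC(=O)NCCCC(C)Nc2cc(OC)cc3cccnc23)c2ccccc2)cc1` gives 5000 nM in this assay, a difference from compound 3 that is beyond the scatter. Compound 2 `COc1cc(NC(C)CCCNC(=O)NNC(=O)Nc2ccc(Cl)c(C(F)(F)F)c2)c2ncccc2c1`, which extends the same chain through an aryl urea, gives 2000 nM in this assay, the lowest of the three numbers and again beyond the scatter relative to compound 3. Compound 4 `COc1cc(NC(C)CCCNC(=O)NNC(=O)NCCCO)c2ncccc2c1` is the next compound, not yet measured in this assay. It differs from compound 3 in one place: (3-hydroxypropyl)carbamoyl in place of hydrogen on an amine nitrogen. Going by the values given here, the only precedent for building out from this nitrogen is compound 2, whose value of 2000 nM lies well under that of compound 3, so a modest gain is expected for compound 4, with the step from compound 3 to compound 4 estimated as a 2.0-fold lower number from compound 3 to compound 4 (0.30 log units; within the scatter). In this assay compound 4 is expected to give about 8000 nM, within a range of 3000 nM to 20000 nM.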

Compound 4, half-maximal inhibitory concentration: 13000 nM
Compound 4: the middle estimate sits 1.6-fold (0.21 log units) below what was measured; measured number inside the range.
By their numbers in this assay, from the lowest: compound 2; then compound 1; then compounds 4 and 3 (each within the scatter of the next).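

Building out from this amine nitrogen does not by itself shift the number in this assay: the (3-hydroxypropyl)carbamoyl group gives a 1.2-fold lower number from compound 3 to compound 4 (0.09 log units; within the scatter), so the added carbamoyl alone does not bring the gain seen with compound 2. What stands on the amide-type nitrogen at the far end does matter, as 3-hydroxypropyl in place of 4-chloro-3-(trifluoromethyl)phenyl gives a 6.5-fold higher number from compound 2 to compound 4 (0.81 log units; beyond the scatter). No measurement here accounts for this difference.

The compounds shown leave open whether the gap follows from the phenyl ring itself or from its chloro and trifluoromethyl groups, a question that a plain phenyl on the same nitrogen would address. They also leave open whether a longer chain, or an amine or a carboxylic acid in place of the hydroxy group of 3-hydroxypropyl, would move the number away from that of compound 3.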